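This account rests on a few compounds, and the source may have more. Where it says the series, first, only, none or still open, it means among the compounds named here.

Three compounds have been measured in an assay on HEK293 cells for inhibition of sodium channel protein type 3 subunit alpha (Homo sapiens), read by electrophysiology, with a stated time of 3.5 min; a higher number here means a weaker inhibitor, a lower number a stronger inhibitor:

Compound 1 `NC(=O)[C@@H]1CC[C@H](c2ccc(OCc3ccc(F)cc3)cc2)N1` gives > 63000 nM, which is a limit of the assay rather than a number.
Compound 2 `NC(=O)[C@@H]1CC[C@H](c2ccc(OCc3ccccc3F)cc2F)N1` gives > 100000 nM, again a limit of the assay rather than a number.
Compound 3 `NC(=O)CNCc1ccc(OCc2ccccc2F)cc1` gives 50100 nM.

Compound 1 therefore stands only at a limit in this assay, and of the other two values shown, one is also a limit (the limit of > 100000 nM in this assay, at which 1 of the 3 values shown sits), while only compound 3 has a definite number. Among the measured compounds shown here, this leaves little to anchor a comparison, and no step between two measured compounds can be followed.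

Compound 4 `NC(=O)[C@@H]1CC[C@H](c2ccc(OCc3cccc(F)c3)cc2)N1` differs from compound 1 in one place: 3-fluorophenyl in place of 4-fluorophenyl on a saturated chain carbon bound to an oxygen on an aromatic ring. Both compounds keep the same core and the same amide, and the fluorine simply moves to another position on the outer ring.

For the measured compounds named here, with no measured step of this kind to draw on, the expectation is for no change beyond the usual scatter, in either direction. Compound 4 is thus expected to show about 70000 nM in this assay, with a likely range from 30000 nM to 160000 nM. This corresponds to an expected step that the limit leaves unreadable from compound 1 to compound 4, and it is quite possible that the assay again reports only a limit rather than a number.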

Compound 4, half-maximal inhibitory concentration: > 100000 nM
Compound 4: only a limit was reported; the forecaster's own chance of this, stated with the estimate: 65%; middle value at least 1.4-fold (0.15 log units) from the limit.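

In this assay compound 4 gives > 100000 nM, which is a limit of the assay and not a number. Among the compounds shown here, compound 1 also gives only a limit, > 63000 nM, so no step from compound 1 to compound 4 can be read. The compounds shown leave open whether 3-fluorophenyl and 4-fluorophenyl differ at all in this assay.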